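Exchanging fluoro for bromo on compound 2

A few compounds are considered here, and "the series" means these few. Any claim that something is new, unique, unknown or untested is made for them only; others in the source may bear on it.

In an ADME assay on cells (Hepatocyte, Mus musculus) for cytotoxicity, read by MTT assay, with a stated time of 24 h (on this read-out lower numbers stand for higher toxicity in this test and higher numbers for lower toxicity in this test), compound 1 (`Cc1ccc(-c2nn(-c3ccccc3)cc2-c2nc3ccccc3n2S(=O)(=O)c2ccc(Br)cc2)cc1`) gives only a limit of the assay, > 300000 nM. Within the data shown here, compound 2 (`O=S(=O)(c1ccc(F)cc1)n1c(-c2cn(-c3ccccc3)nc2-c2ccc(F)cc2)nc2ccccc21`) gives 174000 nM, the only actual number available, so it has no numerical neighbour to be ranked against. Compound 3 (`O=S(=O)(c1ccc(Br)cc1)n1c(-c2cn(-c3ccccc3)nc2-c2ccc(F)cc2)nc2ccccc21`) has not yet been measured. It departs from compound 2 by a single exchange, (4-fluorophenyl)sulfonyl to (4-bromophenyl)sulfonyl: bromo in place of fluoro on an aromatic carbon. Among the measured compounds shown here, no measured pair isolates this change. Compound 1 already carries the (4-bromophenyl)sulfonyl group, and its limit of > 300000 nM gives a weak reason to expect no gain in toxicity. The expected change is a 1.2-fold higher number from compound 2 to compound 3 (0.08 log units; within the scatter), a small move toward lower toxicity in this test that may not exceed the usual scatter. For compound 3 the estimated value is 210000 nM, with an expected range from 110000 nM to 300000 nM.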

Compound 3, half-maximal cytotoxic concentration: > 300000 nM
Compound 3 gave a limit, no number; the forecaster's own chance of this, stated with the estimate: 30%; middle value at least 1.4-fold (0.15 log units) away from the limit.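

Among these compounds, with this pair, bromo in place of fluoro on an aromatic carbon is isolated for the first time, para to a large group, and in this assay it reads as an at least 1.7-fold higher number from compound 2 to compound 3 (0.23 log units; that floor lies within the scatter). Compound 3 gives > 300000 nM, which is a limit of the assay and not a number. The step therefore has only a floor, it shows no move toward higher toxicity in this test, and how far the true value lies past that floor cannot be told: the limit of > 300000 nM in this assay, at which 2 of the 3 values shown sit.

The step from compound 1 to compound 3 cannot be read, as both values are limits. As far as these compounds go, whether chloro, an amine or a carboxylic acid at this same place would give a number rather than a limit stays open.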